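A few compounds are considered here, and "the series" means these few. Any claim that something is new, unique, unknown or untested is made for them only; others in the source may bear on it.

Working notes: in a functional assay on A549 cells (Homo sapiens) for inhibition, read by sulforhodamine B assay, with a stated time of 72 h (on this read-out higher numbers stand for weaker inhibition of growth and lower numbers for stronger inhibition of growth), compound 3 `CNC(=O)CCc1ccncc1-c1ccc2ccccc2c1` gives 10400 nM and compound 2 `CNC(=O)/C=C/c1ccncc1-c1ccc2ccccc2c1` gives 6620 nM, two values within the scatter of each other. Compound 1 `CN1CCN(C(=O)/C=C/c2ccncc2-c2ccc3ccccc3c2)CC1` reads > 10000 nM, which is a limit of the assay. Compound 4 `COC(=O)/C=C/c1ccncc1-c1ccc2ccccc2c1` carries 2-(methoxycarbonyl)ethenyl in place of 2-(methylcarbamoyl)ethyl on an aromatic carbon, opposite the ring nitrogen (2-(methoxycarbonyl)ethenyl in place of 2-(methylcarbamoyl)ethyl on an aromatic carbon). Going by the values given here, two measured steps bear on this change: a 1.6-fold higher number from compound 2 to compound 3 (0.20 log units; within the scatter) and an at least 1.5-fold lower number from compound 1 to compound 2 (0.17 log units; that floor lies within the scatter). Both stay within the scatter, though no methoxycarbonyl group has been measured in the series yet. On that basis, no change beyond the scatter is expected, and the expected step is a 1.6-fold lower number from compound 3 to compound 4 (0.20 log units; within the scatter). For compound 4 the estimated value is 6500 nM, with an expected range of 2500 nM to 15000 nM.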

Compound 4, concentration for 50% growth inhibition: 760 nM
For compound 4 the middle estimate is 8.6-fold (0.93 log units) above the measured one; the whole stated range lies above it.
By their numbers in this assay, from the lowest: compound 4; then compounds 2 and 3 (each within the scatter of the next).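

In this assay, going by these compounds alone, the carbonyl substituent on this chain, opposite the ring nitrogen, is the first change to move the number beyond the scatter: with methoxy in place of methylamino there is an 8.7-fold lower number from compound 2 to compound 4 (0.94 log units; beyond the scatter), and the full replacement of the saturated amide chain gives a 14-fold lower number from compound 3 to compound 4 (1.14 log units; beyond the scatter). Methoxy in place of 4-methylpiperazin-1-yl gives an at least 13-fold lower number from compound 1 to compound 4 (1.11 log units; beyond the scatter). That last step is only a floor, set by a limit: the limit of > 10000 nM in this assay, at which 1 of the 4 values shown sits.

Going by these compounds, whether the ester itself is required remains open. A carboxylic acid, an ethyl ester or the saturated 2-(methoxycarbonyl)ethyl chain would test this.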